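Terminal aryl swap on the diaryl diketone acid series

The compounds below may be only part of what the source reports. "The series", "measured", "known", "first", "only" and "open" are said of these compounds alone.

Compound 1 `O=C(O)c1ccc(C(=O)c2ccc(C(=O)c3ccc(O)cc3)cc2)cc1` carries a hydroxy on its terminal aromatic ring. Among the measured compounds shown here, in an assay on CHO cells for inhibition of 3-oxo-5-alpha-steroid 4-dehydrogenase 2 (Homo sapiens) (on this read-out lower numbers stand for stronger inhibition and higher numbers for weaker inhibition), compound 1 gives 22 nM, the lowest of the two numbers available, though its only neighbour sits within the scatter. That neighbour, compound 2 `O=C(O)c1ccc(C(=O)c2ccc(C(=O)c3ccc(C(F)(F)F)cc3)cc2)cc1`, gives in this assay a value of 30 nM. For the measured compounds named here, the single measured step is a 1.4-fold higher number from compound 1 to compound 2 (0.13 log units; within the scatter), for trifluoromethyl in place of hydroxy on an aromatic carbon.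

Compound 3 `O=C(O)c1ccc(C(=O)c2ccc(C(=O)c3ccc(Cl)cc3Cl)cc2)cc1` has not been measured. It differs from compound 1 by 2,4-dichlorophenyl in place of 4-hydroxyphenyl on a carbonyl carbon. The step from compound 1 to compound 2 is the one that bears on this change: it also removed the hydrogen-bond donor and acceptor from that ring and produced nothing beyond the scatter. Going by the values given here, no measured pair speaks to a second chlorine on the ring, so that part of the change is uncovered. The expectation for compound 3 in this assay is therefore a step no larger than the scatter, leaning to a slightly higher number, a 1.4-fold higher number from compound 1 to compound 3 (0.13 log units; within the scatter). Compound 3 is estimated at 30 nM, with a range from 12 nM to 80 nM.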

Compound 3, inhibition constant: 35 nM
The estimate for compound 3 lay 1.2-fold (0.07 log units) below the measured number, and the stated range covers the measured number.
By their numbers in this assay, from the lowest: compounds 1, 2 and 3 (each within the scatter of the next).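

With a 1.6-fold higher number from compound 1 to compound 3 (0.20 log units; within the scatter) in this assay, the swap on the carbonyl carbon stays inside the scatter even though the entering 2,4-dichlorophenyl has no hydrogen-bond donor or acceptor and carries two chlorine atoms. The earlier step covered only one substituent exchanged for another on that ring, whereas this one adds the measurement that was missing for a ring with a second substituent, and the readout still does not separate compounds 1, 2 and 3, which each sit within the scatter of the next. So far, then, this position has shown no sensitivity to the three terminal rings in hand, and no measurement available gives a reason for that flat reading.

Still open is whether each chlorine of compound 3 would read the same alone, since a ring with a single chlorine does not appear among the compounds shown. Also open, on these data alone, is whether the flat reading would survive a basic amine on the terminal ring, or a longer alkyl chain in place of that ring, either of which could define the limits of this position.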